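A few compounds are considered here, and "the series" means these few. Any claim that something is new, unique, unknown or untested is made for them only; others in the source may bear on it.

Of the compounds shown here, three built on one shared core have been measured in a functional assay on HT-29 cells (Homo sapiens) for cytotoxicity, read by MTT assay, with a stated time of 72 h; on this read-out lower numbers stand for stronger inhibition and higher numbers for weaker inhibition. Compound 1 `Cc1cccc(Cl)c1NC(=O)CN1CCN(c2nnc(Cc3ccncc3)c3ccccc23)CC1` gives 22600 nM. Compound 2 `O=C(CN1CCN(c2nnc(Cc3ccncc3)c3ccccc23)CC1)Nc1ccc(F)c(F)c1` gives 2320 nM, and compound 3 `O=C(CN1CCN(c2nnc(Cc3ccncc3)c3ccccc23)CC1)Nc1ccc(Br)cc1` gives 1990 nM, the lowest of the three numbers; its gap to compound 2 lies within the scatter, whereas the step of an 11-fold lower number from compound 1 to compound 3 (1.06 log units; beyond the scatter) lies beyond it, and the step of a 9.7-fold lower number from compound 1 to compound 2 (0.99 log units; beyond the scatter) likewise.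

Compound 4 `O=C(CN1CCN(c2nnc(Cc3ccncc3)c3ccccc23)CC1)Nc1ccc(F)c(C(F)(F)F)c1` differs from compound 3 by 4-fluoro-3-(trifluoromethyl)phenyl in place of 4-bromophenyl on an amide-type nitrogen. For the measured compounds named here, the steps that bear on this change are those at the same amide-type nitrogen: an 11-fold lower number from compound 1 to compound 3 (1.06 log units; beyond the scatter) and a 1.2-fold lower number from compound 2 to compound 3 (0.07 log units; within the scatter), the latter within the scatter. Because a 1.2-fold lower number from compound 2 to compound 3 (0.07 log units; within the scatter) stays within the scatter while one halogenated phenyl replaces another on that nitrogen, compound 4 is expected to show a step of a 1.3-fold higher number from compound 3 to compound 4 (0.10 log units; within the scatter), not beyond the scatter. Compound 4 is therefore estimated at 2500 nM, with a range from 900 nM to 7000 nM in this assay.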

Compound 4, half-maximal inhibitory concentration: 1110 nM
Compound 4: middle estimate off by 2.3-fold (0.35 log units), on the high side; the measured number falls inside the stated range.
By their numbers in this assay, from the lowest: compounds 4, 3 and 2 (each within the scatter of the next, the first and the last beyond it); then compound 1.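

In this assay, 4-fluoro-3-(trifluoromethyl)phenyl on the amide-type nitrogen gives a 1.8-fold lower number from compound 3 to compound 4 (0.25 log units; within the scatter) and so cannot be told apart from 4-bromophenyl, yet trifluoromethyl in place of fluoro on an aromatic carbon gives a 2.1-fold lower number from compound 2 to compound 4 (0.32 log units; beyond the scatter) and thus a modest step that the comparison of compound 2 with compound 3 did not show. Against 2-chloro-6-methylphenyl the new group gives a 20-fold lower number from compound 1 to compound 4 (1.31 log units; beyond the scatter) and this is the largest step seen at this position so far. No measurement available here explains these differences.

The compounds shown leave open whether this nitrogen also tolerates a phenyl ring carrying an amine or a carboxylic acid, or a benzyl group in place of phenyl. They also leave open whether the chloro or the methyl of 2-chloro-6-methylphenyl accounts for the high number of compound 1.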